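The source may report more compounds than this note shows. Statements on the series, on what has been measured and on what is new or still open speak of the compounds shown alone.

Measured so far:
compound 1 `CCN1CCN(C[C@H]2CN(c3ccc(-n4cc(-c5ccccn5)cn4)c(F)c3)C(=O)O2)CC1`: 99 ug/mL
compound 2 `O=C(OC[C@H]1CN(c2ccc(-n3cc(-c4ccccn4)cn3)c(F)c2)C(=O)O1)c1ccccc1`: > 400 ug/mL
compound 3 `O=C1O[C@@H](CSc2cccs2)CN1c1ccc(-n2cc(-c3ccccn3)cn2)c(F)c1`: > 400 ug/mL

In an ADME assay on HEK293-A cells (Homo sapiens) for cytotoxicity, read by MTT assay, with a stated time of 48 h (a lower number here means a stronger inhibitor, a higher number a weaker inhibitor), compound 1 gives 99 ug/mL. Compound 2 reaches only a limit of the assay, > 400 ug/mL. Compound 3 stands at the same kind of limit, > 400 ug/mL. Both steps away from compound 1 are therefore read as bounds: an at least 4.0-fold higher number from compound 1 to compound 2 (0.60 log units; beyond the scatter) and an at least 4.0-fold higher number from compound 1 to compound 3 (0.60 log units; beyond the scatter). Between the two limit compounds nothing can be read: a step that the two limits leave unreadable from compound 2 to compound 3. This follows from the limit of > 400 ug/mL in this assay, at which 2 of the 3 values shown sit.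

Compound 4 `CCNC(=O)NC[C@H]1CN(c2ccc(-n3cc(-c4ccccn4)cn3)c(F)c2)C(=O)O1` differs from compound 3 in one place: (ethylcarbamoyl)amino in place of (thiophen-2-yl)sulfanyl on a saturated chain carbon bound to a saturated ring carbon. Within the data shown here, no measured step carries this particular exchange, so the expectation rests on the fact that two of three variants at this chain carbon sit at the limit and only compound 1 gives a number. Compound 4 is expected to behave like compound 2 and compound 3 rather than compound 1, so the step of an at least 1.2-fold lower number from compound 3 to compound 4 (0.09 log units; that floor lies within the scatter) is expected to be small or unreadable. The estimate for compound 4 in this assay is 320 ug/mL, within 100 ug/mL to 400 ug/mL.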

Compound 4, half-maximal inhibitory concentration: 29 ug/mL
Compound 4: middle estimate off by 11-fold (1.04 log units), on the high side, outside the stated range (below it).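

Among these compounds, at this saturated chain carbon bound to a saturated ring carbon, 4-ethylpiperazin-1-yl is no longer the only group to give a number in this assay: (ethylcarbamoyl)amino does too, with a 3.4-fold lower number from compound 1 to compound 4 (0.53 log units; beyond the scatter). The same group gives an at least 13-fold lower number from compound 3 to compound 4 (1.13 log units; beyond the scatter) and an at least 13-fold lower number from compound 2 to compound 4 (1.13 log units; beyond the scatter), and in the first of these exchanges the heavy-atom count stays the same, so that count alone does not set the result. These last two steps are floors and not full sizes because compound 2 and compound 3 sit at a limit: the limit of > 400 ug/mL in this assay, at which 2 of the 4 values shown sit.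

The compounds shown do not separate the loss of the ring from the entry of the hydrogen-bond donors in (ethylcarbamoyl)amino. An acetamide, a primary amine or a longer chain in place of the ethyl group at this carbon would bear on that question.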